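A few compounds are considered here, and "the series" means these few. Any claim that something is new, unique, unknown or untested is made for them only; others in the source may bear on it.

Measured in a functional assay on HL-60 cells (Homo sapiens) for inhibition, read by MTT assay, with a stated time of 72 h, tested at 30 uM; a lower number here means less inhibition of growth, a higher number more inhibition of growth at the concentration tested:
- compound 1 `C=CCc1ccc(OCc2cn(-c3ccc(C#N)cc3)nn2)c(O)c1`: 20.8%
- compound 2 `C=CCc1ccc(OCc2cn(-c3ccccc3Cl)nn2)c(O)c1`: 38.7%
- compound 3 `C=CCc1ccc(OCc2cn(-c3ccccc3CO)nn2)c(O)c1`: 31.7%

Compound 3 stands within the scatter of compound 2, with a number 7 percentage points lower from compound 2 to compound 3 (within the scatter), but clear of compound 1, with a number 10.9 percentage points higher from compound 1 to compound 3 (beyond the scatter).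

Compound 4 `C=CCc1ccc(OCc2cn(-c3cccc(C#N)c3)nn2)c(O)c1` carries 3-cyanophenyl in place of 2-(hydroxymethyl)phenyl on an aromatic nitrogen.

Among the compounds with values here, no measured compound carries 3-cyanophenyl. Within the data shown here, the closest guide is compound 1, the only measured compound with a nitrile, and a number 10.9 percentage points higher from compound 1 to compound 3 (beyond the scatter) read in reverse points to a lower number. With the nitrile placed differently, a smaller drop than that is expected in this assay, probably not beyond the scatter. The expected step is a number 6.7 percentage points lower from compound 3 to compound 4 (within the scatter). Compound 4 is estimated at 25%, with an expected range from 12% to 38%.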

Compound 4, percent growth inhibition at one concentration: 22.5%
The estimate for compound 4 lay 2.5 percentage points above the measured number; measured number inside the range.
By their numbers in this assay, from the lowest: compounds 1, 4, 3 and 2 (each within the scatter of the next, the first and the last beyond it).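

With a number 1.7 percentage points higher from compound 1 to compound 4 (within the scatter) in this assay the place of the nitrile on the phenyl ring makes no readable difference between 3-cyanophenyl and 4-cyanophenyl. Against 2-chlorophenyl, 3-cyanophenyl gives a number 16.2 percentage points lower from compound 2 to compound 4 (beyond the scatter) and against 2-(hydroxymethyl)phenyl it gives a number 9.2 percentage points lower from compound 3 to compound 4 (within the scatter) and so only the gap to the chloro compound stands clear. Nothing available explains these differences.
Open, on these data alone, is how an amine or a carboxylic acid on this phenyl ring would read. Also open, as far as these compounds go, is whether a longer chain in place of the hydroxymethyl would change the number.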